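This account rests on a few compounds, and the source may have more. Where it says the series, first, only, none or still open, it means among the compounds named here.

Measured so far:
compound 1, `CCOC(=O)c1cnc(-c2cc(Cl)nc(Cl)c2)nc1NN1C(=O)C=C(C)C1=O`, in a functional assay on Jurkat cells for inhibition of nuclear factor NF-kappa-B complex (Homo sapiens) (on this read-out lower numbers stand for stronger inhibition and higher numbers for weaker inhibition), gives 2000 nM;
compound 2, `CCOC(=O)c1cnc(-c2csc(C)n2)nc1NN1C(=O)C=C(C)C1=O`, gives 8000 nM;
compound 3, `CCOC(=O)c1cnc(-c2ccc(Cl)cc2)nc1NN1C(=O)C=C(C)C1=O`, gives 300 nM.

Compound 3 stands lowest of the three numbers, and so is the strongest inhibitor measured here: the step of a 6.7-fold lower number from compound 1 to compound 3 (0.82 log units; beyond the scatter) is modest, and the step of a 27-fold lower number from compound 2 to compound 3 (1.43 log units; beyond the scatter) is large, both beyond the scatter. Compound 4, `CCOC(=O)c1cnc(Oc2ccccc2)nc1NN1C(=O)C=C(C)C1=O`, has not yet been measured. It differs from compound 3 in one place: phenoxy in place of 4-chlorophenyl on an aromatic carbon. Among the compounds with values here, none of the measured steps exchanges an aromatic ring for a ring joined through an oxygen at this place, so nothing bears directly on this change. What the measured steps do show is that the group at this place matters: a 4.0-fold higher number from compound 1 to compound 2 (0.60 log units; beyond the scatter) and a 6.7-fold lower number from compound 1 to compound 3 (0.82 log units; beyond the scatter) are both beyond the scatter, and a 27-fold lower number from compound 2 to compound 3 (1.43 log units; beyond the scatter) is large. Every measured departure from the 4-chlorophenyl of compound 3 gave a higher number, so a modest step toward a higher number in this assay is expected, with the direction left uncertain. Compound 4 is therefore expected to give 1500 nM. For compound 4 the expected range runs from 400 nM to 6000 nM. The step expected is a 5.0-fold higher number from compound 3 to compound 4 (0.70 log units; beyond the scatter).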

Compound 4, half-maximal inhibitory concentration: 15000 nM
For compound 4 the middle estimate is 10-fold (1.00 log units) below the measured one; the whole stated range lies below it.
By their numbers in this assay, from the lowest: compound 3; then compound 1; then compounds 2 and 4 (each within the scatter of the next).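

In this assay, phenoxy and 4-chlorophenyl each carry one six-membered aromatic ring of carbon only, yet exchanging them on this carbon between two ring nitrogen atoms brings a 50-fold higher number from compound 3 to compound 4 (1.70 log units; beyond the scatter) and removes most of the inhibition seen with compound 3, so having such a ring here does not by itself secure a low number. Phenoxy also does worse than the 2,6-dichloropyridin-4-yl group, with a 7.5-fold higher number from compound 1 to compound 4 (0.88 log units; beyond the scatter) on that exchange, whereas a 1.9-fold higher number from compound 2 to compound 4 (0.27 log units; within the scatter) means that compound 2 and compound 4 cannot be told apart, and the aromatic rings joined directly at this place therefore span a range that reaches up to the level of the oxygen-linked ring. Nothing available explains the size of these steps.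

The exchange changes two things at once, since an oxygen enters as the link and the chlorine leaves, and the compounds shown cannot separate these two changes; an unsubstituted phenyl or a 4-chlorophenoxy group would pull them apart. Going by these compounds, it also stays open whether another link at this place, such as an amine or a sulfur atom carrying the same phenyl ring, would behave like the oxygen.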